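A few compounds are considered here, and "the series" means these few. Any claim that something is new, unique, unknown or untested is made for them only; others in the source may bear on it.

Measured so far:
compound 1 `COc1cc(Cl)cc(-c2nn(-c3cccc(NC(=O)Nc4ccc(Cl)c(C(F)(F)F)c4)c3)cc2-c2ccncc2)c1`, in a functional assay on M14 cells (Homo sapiens) for inhibition, read by sulforhodamine B assay, with a stated time of 48 h, tested at 0.01 uM (on this read-out higher numbers stand for a weaker effect at the one concentration tested and lower numbers for a stronger effect), compound 1 gives 97%.
compound 2 `COc1cc(Cl)cc(-c2nn(-c3cccc(NC(=O)Nc4cccc(C(F)(F)F)c4)c3)cc2-c2ccncc2)c1`, in this assay compound 2 gives 98%.

Compound 2 holds the highest of the two numbers, its nearest neighbour being compound 1 at a step of a number 1 percentage points higher from compound 1 to compound 2 (within the scatter), so the two read alike. Compound 3 `COc1cc(Cl)cc(-c2nn(-c3cccc(NC(=O)c4cccc(C(F)(F)F)c4)c3)cc2-c2ccncc2)c1` differs from compound 2 by 3-(trifluoromethyl)phenyl in place of (3-(trifluoromethyl)phenyl)amino on a carbonyl carbon. Among the compounds with values here, no measured step touches this carbonyl position; the only step known, hydrogen in place of chloro, stayed within the scatter. Both measured numbers sit near the top of the read-out, leaving little room for movement upward. A step of a number 3 percentage points lower from compound 2 to compound 3 (within the scatter) is expected, none beyond the scatter. Compound 3 is estimated at 95%, within 80% to 105%.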

Compound 3, a percentage reported as activity, at one concentration (the size of the read-out at that concentration, not a potency): 101%
Beside the measured number, compound 3's estimate is 6 percentage points below it; measured number inside the range.
By their numbers in this assay, from the lowest: compounds 1, 2 and 3 (each within the scatter of the next).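

In this assay, 3-(trifluoromethyl)phenyl in place of (3-(trifluoromethyl)phenyl)amino on the carbonyl carbon gives a number 3 percentage points higher from compound 2 to compound 3 (within the scatter) and, with the chloro group also gone, a number 4 percentage points higher from compound 1 to compound 3 (within the scatter) as the second reading of this position. The carbonyl position, untouched by the earlier step, can thus lose the amino nitrogen and its hydrogen-bond donor with no change beyond the scatter, though all three compounds read alike at the weak end. Nothing available explains this result.

Open, on these data alone, is whether a piperidine or a longer alkyl chain on this carbonyl carbon would shift the number. Also open, as far as these compounds go, is how these compounds compare at other concentrations.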